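The source may report more compounds than this note shows. Statements on the series, on what has been measured and on what is new or still open speak of the compounds shown alone.

The study concerns a set of compounds built on the shared core of compound 1 `CCn1c(/C=C2\SC(=O)N(CC(=O)N3CCCCC3)C2=O)nc2ccccc21`, tested in a functional assay on DU-145 cells (Homo sapiens) for inhibition, read by MTT assay, with a stated time of 48 h; on this read-out lower numbers stand for stronger inhibition and higher numbers for weaker inhibition. In this assay compound 1 gives > 50000 nM, which is a limit of the assay and not a number. Compound 2 `Cn1c(/C=C2\SC(=O)N(CC(=O)N3CCCCC3)C2=O)nc2ccccc21` differs from compound 1 by hydrogen in place of methyl on a saturated chain carbon bound to an aromatic nitrogen. In this assay compound 2 gives > 50000 nM, again a limit of the assay. Compound 3 `CCn1c(/C=C2\SC(=O)N(CC(=O)N3CC(C)OC(C)C3)C2=O)nc2ccccc21` differs from compound 1 by 2,6-dimethylmorpholin-4-yl in place of piperidin-1-yl on a carbonyl carbon. In this assay compound 3 gives > 50000 nM, once more a limit of the assay. The measured step that the two limits leave unreadable from compound 1 to compound 2 therefore cannot be sized, because the limit of > 50000 nM in this assay, at which 3 of the 3 values shown sit, is where both of its partners sit.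

Compound 4 `CC1CN(C(=O)CN2C(=O)S/C(=C\c3nc4ccccc4n3C)C2=O)CC(C)O1` has not yet been measured. It stands to compound 3 as compound 2 stands to compound 1: it carries hydrogen in place of methyl on a saturated chain carbon bound to an aromatic nitrogen, the same change at the same place as the step already seen, while the two cores differ by the change already noted between compound 1 and compound 3. Within the data shown here, the earlier step gave nothing readable, and nothing among the measured compounds points to a departure from the limit. Because the limit of > 50000 nM in this assay, at which 3 of the 3 values shown sit, holds every value seen so far, compound 4 is expected to sit there as well. The step of a number no higher from compound 3 to compound 4 (the limit leaves the size open) is accordingly estimated to be of no readable size. Compound 4 is expected to give about 50000 nM, within 20000 nM to 100000 nM, most likely reported only as a limit.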

Compound 4, half-maximal inhibitory concentration: > 50000 nM
Compound 4: no number, only a limit (the forecaster's own chance of this, stated with the estimate: 80%); the middle value sits exactly at the limit.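

In this assay compound 4 gives > 50000 nM, a limit of the assay and not a number, so neither of its steps, from compound 3 or from compound 2, can be read. The compounds shown leave open whether either change, at the chain on the aromatic nitrogen or at the carbonyl carbon, alters inhibition at all, because every value rests on the same limit: the limit of > 50000 nM in this assay, at which 4 of the 4 values shown sit.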